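Swapping the 2-Chlorophenyl Group on Compound 3

A few compounds are considered here, and "the series" means these few. Any claim that something is new, unique, unknown or untested is made for them only; others in the source may bear on it.

Compound 1 `CC1=NN(C(=O)c2ccc(C)cc2)C(c2cc(Br)cc(Br)c2O)C1`: 56500 nM
Compound 2 `CC[N+](C)(CC)CC(=O)N1N=C(C)CC1c1ccccc1OC`: 3320 nM
Compound 3 `O=C(c1ccccc1Cl)N1N=C(c2cc3ccccc3oc2=O)CC1c1ccccc1`: 6640 nM

All three values come from a functional assay on MGC-803 cells (Homo sapiens) for cytotoxicity, read by MTT assay, with a stated time of 48 h; a lower number here means a stronger inhibitor, a higher number a weaker inhibitor. Compound 3, at 6640 nM, cannot be told apart from compound 2, at 3320 nM, since their gap lies within the scatter. Compound 1, at 56500 nM, is a clearly weaker inhibitor than compound 3.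

The next compound is compound 4 `CC(C)(C)NCC(=O)N1N=C(c2cc3ccccc3oc2=O)CC1c1ccccc1`, which has ((tert-butyl)amino)methyl in place of 2-chlorophenyl on a carbonyl carbon. Going by the values given here, no measured pair isolates this change, so any expectation is tentative. Compound 2, at 3320 nM, also has no 2-chlorophenyl on its carbonyl carbon, and its value gives no sign of a large loss of activity relative to compound 3. The step expected in this assay is therefore none beyond the scatter, an estimated 1.3-fold lower number from compound 3 to compound 4 (0.12 log units; within the scatter). The estimate for compound 4 is 5000 nM, with an expected range of 1500 nM to 18000 nM.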

Compound 4, half-maximal inhibitory concentration: 15400 nM
Beside the measured number, compound 4's estimate is 3.1-fold (0.49 log units) below it; measured number inside the range.
By their numbers in this assay, from the lowest: compounds 2 and 3 (each within the scatter of the next); then compound 4; then compound 1.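

Going by these compounds alone, this is the first step that isolates a single place: in this assay, ((tert-butyl)amino)methyl in place of 2-chlorophenyl on a carbonyl carbon gives a 2.3-fold higher number from compound 3 to compound 4 (0.37 log units; beyond the scatter). The step is modest, so this position accepts a group with no ring and with a hydrogen-bond donor and acceptor, which 2-chlorophenyl lacks, at a limited cost in this assay. No measurement shown here accounts for the change in activity.

The compounds shown leave open which part of the change carries the step: the loss of the ring, the loss of the chlorine or the entry of the amine nitrogen. A plain phenyl group or a (diethylamino)methyl group on the same carbonyl carbon would begin to separate these parts.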